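Extending the chain from compound 3 to compound 4

The source may hold more compounds than are shown below. What is called first, only, known or untested is meant among the compounds shown, and "the series" means these compounds.

In a functional assay on MGC-803 cells (Homo sapiens) for antiproliferative activity, read by MTT assay, with a stated time of 48 h (on this read-out higher numbers stand for weaker inhibition and lower numbers for stronger inhibition), compound 3 `CCCCCCCCCn1cc(COC[C@@H]2OC[C@H](N)[C@H]2O)nn1` gives > 128000 nM, which is a limit and not a number. Compound 2 `CCCCCCCCn1cc(COC[C@@H]2OC[C@H](N)[C@H]2O)nn1` gives > 128000 nM, which is also a limit. Going by the values given here, the one measured step that bears on the change is a step that the two limits leave unreadable from compound 2 to compound 3, so it offers no size to carry forward. The evidence on the set is thin: the limit of > 128000 nM in this assay, at which 2 of the 3 values shown sit. Among the compounds with values here, compound 1 `CCCCCCCCCCn1cc(COC[C@@H]2OC[C@H](N)[C@@H]2O)nn1` gives 8780 nM in this assay, the only true number so far.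

Compound 4 `CCCCCCCCCCn1cc(COC[C@@H]2OC[C@H](N)[C@H]2O)nn1` follows by methyl in place of hydrogen on a saturated chain carbon, nine bonds along the chain from an aromatic nitrogen. Compound 1 at 8780 nM shows that this assay can return a number within the set, so a move toward stronger inhibition is expected. For compound 4, a further limit remains quite possible. The expected size is an at least 2.5-fold lower number from compound 3 to compound 4 (0.40 log units; beyond the scatter), an estimate resting on very little. For compound 4 the estimated value is 50000 nM, with an expected range of 10000 nM to 128000 nM.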

Compound 4, half-maximal inhibitory concentration: 57400 nM
Compound 4: middle estimate off by 1.1-fold (0.06 log units), on the low side, within the range that was stated.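

In this assay lengthening the chain in this configuration now gives a readable gain, with the methyl on a saturated chain carbon, nine bonds along the chain from an aromatic nitrogen, giving an at least 2.2-fold lower number from compound 3 to compound 4 (0.34 log units; beyond the scatter) and the ethyl, eight bonds along, giving an at least 2.2-fold lower number from compound 2 to compound 4 (0.34 log units; beyond the scatter). Both steps are only bounds, their true sizes hidden because the shorter compounds sit at a limit: the limit of > 128000 nM in this assay, at which 2 of the 4 values shown sit. At this chain the stereocentre at a saturated ring carbon, drawn S in compound 1 and R in compound 4, carries a 6.5-fold higher number from compound 1 to compound 4 (0.82 log units; beyond the scatter), a step that can be assigned to configuration alone: the fact that compounds 1 and 4 differ only in the configuration as drawn.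

From the compounds shown here alone, the true size of the chain steps remains open, as does whether the gain continues with a longer chain. Also open, going by these compounds, is whether the configuration of compound 1 keeps its advantage on such a chain.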